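This account rests on a few compounds, and the source may have more. Where it says the series, first, only, none or still open, it means among the compounds named here.

Measured so far in an assay on isolated protein for displacement of a labelled ligand from melanin-concentrating hormone receptor 1 (Homo sapiens); on this read-out lower numbers stand for stronger inhibition and higher numbers for weaker inhibition:
compound 1 `CN(c1ccc2cc(NC(=O)CCc3ccc(C(F)(F)F)cc3)ccc2n1)C1CCCCC1` gives 18 nM;
compound 2 `O=C(CCc1ccc(C(F)(F)F)cc1)Nc1ccc2nc(N3CCC(c4ccccc4)C3)ccc2c1` gives 25 nM.

Compound 2 stands at the upper end of the two numbers shown, though its gap to compound 1, a 1.4-fold higher number from compound 1 to compound 2 (0.14 log units; within the scatter), does not exceed the scatter. Compound 3 `O=C(CCc1ccc(C(F)(F)F)cc1)Nc1ccc2nc(N3CCCCCC3)ccc2c1` differs from compound 2 in one place: azepan-1-yl in place of 3-phenylpyrrolidin-1-yl on an aromatic carbon. For the measured compounds named here, the only measured step bearing on this position is a 1.4-fold higher number from compound 1 to compound 2 (0.14 log units; within the scatter), an exchange of one amine for another on an aromatic carbon that left the number essentially unchanged. Azepan-1-yl lacks the six-membered aromatic ring of carbon only carried by 3-phenylpyrrolidin-1-yl, so a modest rise is expected, the step estimated as a 1.4-fold higher number from compound 2 to compound 3 (0.15 log units; within the scatter). Compound 3 is therefore expected near 35 nM, between 12 nM and 100 nM.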

Compound 3, half-maximal inhibitory concentration: 36 nM
For compound 3 the middle estimate is 1.0-fold (0.01 log units) below the measured one; measured number inside the range.
By their numbers in this assay, from the lowest: compounds 1, 2 and 3 (each within the scatter of the next).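

In this assay, azepan-1-yl in place of 3-phenylpyrrolidin-1-yl gives a 1.4-fold higher number from compound 2 to compound 3 (0.16 log units; within the scatter), so at this position on the shared core, the six-membered aromatic ring of carbon only is not required to stay within the scatter. Azepan-1-yl in place of cyclohexyl(methyl)amino gives a 2.0-fold higher number from compound 1 to compound 3 (0.30 log units; within the scatter), so all three amines remain within the scatter of one another. Nothing available explains this tolerance.

Still open, as far as these compounds go, is whether a much smaller amine, such as dimethylamino, or a ring carrying a second nitrogen, such as piperazin-1-yl, would keep the number in this range. From the compounds shown here alone, the effect of a carboxylic acid on the azepane ring is also open.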